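The source may report more compounds than this note shows. Statements on the series, on what has been measured and on what is new or still open speak of the compounds shown alone.

Of the compounds shown here, three have numbers so far in a functional assay on KB cells (Homo sapiens) for cytotoxicity; a lower number here means a stronger inhibitor, a higher number a weaker inhibitor. Compound 1 (`CCCOC1=CC(=O)c2ccccc2C1=O`) gives 49400 nM, the weakest of the three, with both gaps beyond the usual scatter. Compound 2 (`Cc1ccc(S(=O)(=O)Oc2cccc3c2C(=O)C=CC3=O)cc1`) gives 10700 nM and compound 3 (`C=CCOc1ccc2c(c1)C(=O)C=CC2=O`) gives 10200 nM, two values within the scatter of each other. Compound 4 (`O=C1C=C(Oc2ccco2)C(=O)c2ccccc21`) carries furan-2-yl in place of propyl on an oxygen on an unsaturated carbon. Among the compounds with values here, no measured pair tests a change of this kind, so the expectation is loose. A moderate move toward stronger inhibition in this assay is expected, resting only on compound 3 at 10200 nM showing that this series can reach lower numbers. The estimated step is a 2.7-fold lower number from compound 1 to compound 4 (0.44 log units; beyond the scatter). For compound 4 the estimated value is 18000 nM, with an expected range of 6000 nM to 50000 nM.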

Compound 4, half-maximal inhibitory concentration: 53400 nM
For compound 4 the middle estimate is 3.0-fold (0.47 log units) below the measured one; measured number above the stated range.
By their numbers in this assay, from the lowest: compounds 3 and 2 (each within the scatter of the next); then compounds 1 and 4 (each within the scatter of the next).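

In this assay, furan-2-yl in place of propyl on an oxygen on an unsaturated carbon gives a 1.1-fold higher number from compound 1 to compound 4 (0.03 log units; within the scatter), so adding a five-membered aromatic ring and a hydrogen-bond acceptor at this position leaves the number within the scatter. Within the data shown here, this is the first one-place step, and it shows no separation between these two groups. No measured evidence bears on this result.

From the compounds shown here alone, whether an amine, a carboxylic acid or a longer chain on the same oxygen would shift the number remains open. Also open, going by these compounds, is whether this swap reads the same on another core.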